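The compounds below may be only part of what the source reports. "The series", "measured", "known", "first", "only" and "open" are said of these compounds alone.

Working notes on the series. Of the compounds shown here, two carry numbers so far. Compound 1 `COC(=O)c1cccc(-c2cnc(C(O)CCc3ccc(-c4ccccc4)cc3)o2)n1` gives 9000 nM in an assay for inhibition of Fatty-acid amide hydrolase 1 (Rattus norvegicus); on this read-out lower numbers stand for stronger inhibition and higher numbers for weaker inhibition. Compound 2 `COC(=O)c1ccc(-c2cnc(C(=O)CCc3ccc(-c4ccccc4)cc3)o2)nc1` gives 2.2 nM in this assay, the lowest of the two numbers, and the gap to compound 1 lies well beyond the scatter of repeated measurements. Compound 3 `CS(=O)(=O)c1cnc(C(=O)CCc2ccc(-c3ccccc3)cc2)o1` is the next compound to be measured. It differs from compound 2 in one place: methylsulfonyl in place of 5-(methoxycarbonyl)pyridin-2-yl on an aromatic carbon. Among the measured compounds shown here, no step of this kind has been measured, so the size of the change is open. A moderate rise is expected in this assay, estimated as a 14-fold higher number from compound 2 to compound 3 (1.13 log units; beyond the scatter), beyond the scatter yet much smaller than the gap separating the two measured compounds. The estimate for compound 3 in this assay is 30 nM, with a range from 5 nM to 200 nM.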

Compound 3, inhibition constant: 1.2 nM
The estimate for compound 3 lay 25-fold (1.40 log units) above the measured number; the whole stated range lies above it.
By their numbers in this assay, from the lowest: compounds 3 and 2 (each within the scatter of the next); then compound 1.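

In this assay, the step is a 1.8-fold lower number from compound 2 to compound 3 (0.26 log units; within the scatter), so on the aromatic carbon next to the ring oxygen, methylsulfonyl and 5-(methoxycarbonyl)pyridin-2-yl cannot be told apart. This position therefore carries a group of 4 heavy atoms with no ring as well as one of 10 heavy atoms with a six-membered aromatic ring, and neither that ring nor the methoxycarbonyl is needed for a number of this size on the shared core. Nothing measured speaks to why the two groups read alike.

From the compounds shown here alone, whether a hydrogen, a methyl group, an amine or a carboxylic acid at this position would hold the number remains open. Also open, going by these compounds, is how a hydroxyl group in place of the carbonyl would read with methylsulfonyl kept as the only other feature of the core.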